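Carboxamide-bearing piperidine replaces ethylamine on a pyrazoline amide

The source may hold more compounds than are shown below. What is called first, only, known or untested is meant among the compounds shown, and "the series" means these compounds.

Measured compounds:
compound 1, `CC1=NN(C(=O)CN2CCN(C(=O)OC(C)(C)C)CC2)C(c2ccccc2O)C1`: 5000 nM
compound 2, `CC[N+](C)(CC)CC(=O)N1N=C(C)CC1c1ccccc1OC`: 3670 nM
compound 3, `CCNCC(=O)N1N=C(c2cc3ccccc3oc2=O)CC1c1ccccc1`: 30600 nM

In a functional assay on HepG2 cells (Homo sapiens) for cytotoxicity, read by MTT assay, with a stated time of 48 h (a lower number here means a stronger inhibitor, a higher number a weaker inhibitor), compound 3 gives the highest of the three numbers; compound 1 and compound 2 both sit well beyond the scatter below it. Compound 4, `NC(=O)C1CCN(CC(=O)N2N=C(c3cc4ccccc4oc3=O)CC2c2ccccc2)CC1`, has not yet been measured. It differs from compound 3 by 4-carbamoylpiperidin-1-yl in place of ethylamino on a saturated chain carbon bound to a carbonyl carbon. For the measured compounds named here, no pair of measured compounds shares this change, so its effect has to be guessed. Compound 1, which also carries a six-membered non-aromatic ring with one hetero atom on the chain carbon bound to the carbonyl carbon, gives 5000 nM, but its core differs, so it gives only a loose hint. The expected step of a 1.7-fold lower number from compound 3 to compound 4 (0.23 log units; within the scatter) is a modest lowering, possibly within the scatter. Compound 4 is estimated at 18000 nM, between 5000 nM and 60000 nM.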

Compound 4, half-maximal inhibitory concentration: 19300 nM
Beside the measured number, compound 4's estimate is 1.1-fold (0.03 log units) below it; measured number inside the range.
By their numbers in this assay, from the lowest: compounds 2 and 1 (each within the scatter of the next); then compounds 4 and 3 (each within the scatter of the next).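

In this assay, the step to the much larger 4-carbamoylpiperidin-1-yl on a saturated chain carbon bound to a carbonyl carbon is a 1.6-fold lower number from compound 3 to compound 4 (0.20 log units; within the scatter), so the two compounds stay within the scatter of each other. For the compounds shown here, this is the first direct evidence that this position tolerates a six-membered non-aromatic ring on the shared core, which the loose comparison with compound 1 could not show. No measurement given here explains this result. From the compounds shown here alone, whether the carboxamide matters remains open: an unsubstituted piperidine or a carboxylic acid in its place would separate its contribution from that of the ring.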